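The compounds below may be only part of what the source reports. "The series", "measured", "known", "first", "only" and "open" are said of these compounds alone.

Compound 1 (`COc1cc(-c2nccn2C)cc(OC)c1OC`) gives > 100000 nM in a functional assay on MDA-MB-468 cells (Homo sapiens) for antiproliferative activity, read by MTT assay, with a stated time of 72 h (on this read-out lower numbers stand for stronger inhibition and higher numbers for weaker inhibition), which is a limit of the assay and not a number. This places it at the limit of > 100000 nM in this assay, at which 2 of the 3 values shown sit. Compound 2 (`COc1cc(-c2nccn2CC(C)C)cc(OC)c1OC`) gives > 100000 nM, also a limit. Among the compounds with values here, the only measured step, a step that the two limits leave unreadable from compound 1 to compound 2, therefore gives no size to carry forward. Compound 3 (`COc1cc(-c2nccn2-c2ccc3sccc3c2)cc(OC)c1OC`), with an aromatic group on the aromatic nitrogen, gives a true number of 400 nM.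

Compound 4 (`COc1cc(-c2nccn2-c2ccc(C)cc2)cc(OC)c1OC`) differs from compound 1 by 4-methylphenyl in place of methyl on an aromatic nitrogen, with 4-methylphenyl in place of methyl on an aromatic nitrogen. Within the data shown here, no readable step bears on this change, so the expectation rests on the single value of compound 3 at 400 nM. A shift towards stronger inhibition is expected, probably to a measurable value, though a limit cannot be excluded. The expected move is an at least 66-fold lower number from compound 1 to compound 4 (1.82 log units; beyond the scatter). For compound 4 the estimate is 1500 nM, with an expected range of 200 nM to 15000 nM.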

Compound 4, half-maximal inhibitory concentration: 400 nM
For compound 4 the middle estimate is 3.8-fold (0.57 log units) above the measured one; the measured number falls inside the stated range.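

Replacing methyl with 4-methylphenyl on the aromatic nitrogen in this assay gives an at least 250-fold lower number from compound 1 to compound 4 (2.39 log units; beyond the scatter), and replacing isobutyl with the same group gives an at least 250-fold lower number from compound 2 to compound 4 (2.39 log units; beyond the scatter). Both sizes are lower bounds, since each starts from a limit of the assay and not from a number: the limit of > 100000 nM in this assay, at which 2 of the 4 values shown sit. Compound 3 and compound 4 print the same value, 400 nM, so two different aromatic groups on this nitrogen now give a true number. Compound 1 with methyl and compound 2 with isobutyl give only a limit of the assay.

Open, on these data alone, is what the methyl of 4-methylphenyl contributes, a question that a plain phenyl or a 4-methoxyphenyl on the same nitrogen would address. Also open, as far as these compounds go, is whether a benzyl group on this nitrogen would read with the chains or with the aromatic groups.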